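Fluoro added to the phenoxy ring of compound 1

The source may hold more compounds than are shown below. What is called first, only, known or untested is meant among the compounds shown, and "the series" means these compounds.

Compound 1 `S=C(N/N=C/c1ccc(Oc2ccccc2)cc1)Nc1ccc(Cl)cc1` heads the pair measured so far in a physicochemical assay for lipophilicity, in phosphate buffer, measured as octanol-water partition, with a stated time of 24 h; a higher number here means a more lipophilic compound, a lower number a more polar compound: in this assay compound 1 gives 5.64. Among the measured compounds shown here, its only measured neighbour is compound 2 `Fc1ccc(NC(=S)N/N=C/c2ccc(Oc3ccccc3)cc2)cc1`, which in this assay gives 5.09; the one step recorded, a number 0.55 log units lower from compound 1 to compound 2 (beyond the scatter), is fluoro in place of chloro on an aromatic carbon and runs beyond the scatter.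

Compound 3 `Fc1ccc(Oc2ccc(/C=N/NC(=S)Nc3ccc(Cl)cc3)cc2)cc1` is not yet measured. It departs from compound 1 by fluoro in place of hydrogen on an aromatic carbon, a fluoro in place of hydrogen on an aromatic carbon, para to a large group on the phenoxy ring, so the change reads phenoxy to 4-fluorophenoxy. For the measured compounds named here, no measured step has the same change; the recorded step concerns fluoro replacing chloro, not fluoro replacing hydrogen, so it offers no direct guide. With a single added fluorine and no new donor or acceptor, the expected movement in this assay is small, an estimated step of a number 0.16 log units higher from compound 1 to compound 3 (within the scatter), that is within the scatter or a little above it.

For compound 3 the estimated partition coefficient is 5.8, expected to lie between 5.55 and 6.05.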

Compound 3, partition coefficient: 5.84
Estimate against measurement, compound 3: 0.04 log units below; low and high end bracket the measured number.
By their numbers in this assay, from the lowest: compound 2; then compounds 1 and 3 (each within the scatter of the next).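

Phenoxy to 4-fluorophenoxy gives the first reading at the phenoxy ring of compound 1: in this assay the move runs a number 0.20 log units higher from compound 1 to compound 3 (within the scatter) and so cannot be told apart from repeat measurement. Among the compounds shown here, the only earlier step, a number 0.55 log units lower from compound 1 to compound 2 (beyond the scatter) on the chloro-bearing ring, is a different change at a different place and lies beyond the scatter, so the series now holds one substitution that registers and one that does not, with no basis yet for a rule about either ring. No measured data on the cause of either result are available here.

With fluoro as the only group shown on the phenoxy ring, it remains open whether a methoxy, a trifluoromethyl, an amine or a carboxylic acid in the same place would also stay within the scatter or would carry the number clear of it. For the compounds shown here, it also remains open whether fluoro in place of hydrogen on the phenoxy ring of compound 2 would give a step of similar size to the one seen on compound 1.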